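A few compounds are considered here, and "the series" means these few. Any claim that something is new, unique, unknown or untested is made for them only; others in the source may bear on it.

Compound 1 `COc1ccccc1OCCNc1cnn(Cc2ccc(OC)c(OC3CCCC3)c2)c(=O)c1Cl` was tested in a functional assay on AGS cells (Homo sapiens) for antiproliferative activity, read by MTT assay, with a stated time of 48 h; a lower number here means a stronger inhibitor of growth, a higher number a weaker inhibitor of growth. In this assay compound 1 gives only a limit, > 100000 nM. Compound 2 `COc1ccccc1OCCNc1cnn(Cc2ccc(OC(F)F)c(OC3CCCC3)c2)c(=O)c1Cl` also gives only a limit in this assay, > 100000 nM. Compound 3 `COc1ccc(Cn2nc(NCCOc3ccccc3OC)ccc2=O)cc1Br` likewise gives only a limit in this assay, > 100000 nM. For the measured compounds named here, the single measured step, a step that the two limits leave unreadable from compound 1 to compound 2, has no readable size because both of its compounds sit at the limit of > 100000 nM in this assay, at which 3 of the 3 values shown sit. Compound 4 `COc1ccccc1OCCNc1cnn(Cc2ccc(OC)c(-c3cccc(Cl)c3)c2)c(=O)c1Cl` differs from compound 1 by 3-chlorophenyl in place of cyclopentyloxy on an aromatic carbon. No measured step bears on such a change, and the one step shown is unreadable, so there is no basis to expect compound 4 to move away from the limit. Compound 4 is therefore expected to give 100000 nM, with a range from 30000 nM to 300000 nM. The step expected here is a number no higher from compound 1 to compound 4 (the limit leaves the size open).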

Compound 4, concentration for 50% growth inhibition: > 100000 nM
Compound 4 was reported as a limit; the forecaster's own chance of this, stated with the estimate: 75%; the middle value lies on the limit itself.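

Compound 4, like compound 1, gives only a limit, so the step between them cannot be read: the limit of > 100000 nM in this assay, at which 4 of the 4 values shown sit. The compounds shown leave open which change to the shared core, if any, would give a measurable value in this assay.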